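Methoxy for methyl on a benzyl group: what changes?

The source may report more compounds than this note shows. Statements on the series, on what has been measured and on what is new or still open speak of the compounds shown alone.

Measured so far:
compound 1 `C[C@@H](c1ccccc1)n1cnc2c(N(C)C)ncnc21`: 33%
compound 2 `Cc1ccc(Cn2cnc3c(N(C)C)ncnc32)cc1`: 0%

Two compounds share a core and differ in the group carried on the side chain. In a functional assay on the whole organism for inhibition, with Rattus norvegicus as the target, in the maximal electroshock model, at a dose of 25 mg/kg by the intraperitoneal route (a higher number here means more inhibition at the dose given (going by the name of the read-out), a lower number less inhibition), compound 1 gives 33%. In this assay compound 2 gives 0%, the lowest of the two numbers, and compound 1 stands higher by a gap beyond the scatter.

Compound 3 `COc1ccc(Cn2cnc3c(N(C)C)ncnc32)cc1` has not yet been measured. It differs from compound 2 in one place: methoxy in place of methyl on an aromatic carbon, on an aromatic carbon of a six-membered aromatic ring of carbon only. Among the compounds with values here, no measured pair shows this exact change, so the size of the step is open. A small step is expected, not clearly beyond the scatter, leaning upward if anything, and this is what a number 10 percentage points higher from compound 2 to compound 3 (within the scatter) means here. For compound 3 the estimated value in this assay is 10%, within 0% to 35%.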

Compound 3, a percentage reported as inhibition, in the whole organism at one dose (the size of the read-out at that dose, not a potency): 0%
Beside the measured number, compound 3's estimate is 10 percentage points above it; measured number inside the range.
By their numbers in this assay, from the lowest: compounds 2 and 3 (each within the scatter of the next); then compound 1.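

In this assay, putting methoxy in place of methyl on an aromatic carbon, para to a large group, gives no change at the digits printed from compound 2 to compound 3 (within the scatter). Within the data shown here, this is the first direct reading of this position, and it adds a caution: compound 2 gives 0% and compound 3 gives 0%, so both stand at the bottom of the read-out, and this pair cannot separate the two groups beyond showing no inhibition at this one dose. Nothing given here explains this result.

Still open, as far as these compounds go, is whether an amine or a carboxylic acid at this same place would lift the read-out above the bottom of the scale. Also open, from the compounds shown here alone, is whether a longer chain in place of methoxy would do so.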